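This account rests on a few compounds, and the source may have more. Where it says the series, first, only, none or still open, it means among the compounds named here.

Three compounds of a shared core have been examined in a toxicity assay on the whole organism with Rattus norvegicus as the target, at a dose of 400 mg/kg by the oral route; on this read-out lower numbers stand for a weaker effect and higher numbers for a stronger effect at the one dose given. Compound 1 `Cc1ccccc1OCC1=NCCO1` gives 40% in this assay. Compound 3 `O=[N+]([O-])c1ccccc1OCC1=NCCO1` gives 45% in this assay. The two differ by nitro in place of methyl on an aromatic carbon and the step between them is a number 5 percentage points higher from compound 1 to compound 3 (within the scatter). Compound 2 `Cc1cccc(OCC2=NCCO2)c1` gives 25% in this assay, the lowest of the three numbers, with compound 1 the nearest to it and compound 3 the furthest, both beyond the scatter, so compound 2 stands as the weakest of the three measured. Compound 2 and compound 1 are built from the same atoms joined differently, and the difference between the two cores is not broken down here.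

Compound 4 `O=[N+]([O-])c1cccc(OCC2=NCCO2)c1` has not yet been measured in this assay. From compound 2 it differs by nitro in place of methyl on an aromatic carbon. For the measured compounds named here, this is the same kind of change as the one from compound 1 to compound 3, though not the same: there the entering group sits ortho to a group of 7 heavy atoms, while in compound 4 it sits meta to a group of 7 heavy atoms. Going by the values given here, since the only measured example of this change, from compound 1 to compound 3, is a number 5 percentage points higher from compound 1 to compound 3 (within the scatter), a similarly small step is expected here, a number 5 percentage points higher from compound 2 to compound 4 (within the scatter). Compound 4 is therefore estimated at 30% in this assay, with the expected range running from 15% to 50%.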

Compound 4, a percentage reported as activity, at one dose (the size of the read-out at that dose, not a potency): 80%
Estimate against measurement, compound 4: 50 percentage points below; the whole stated range lies below it.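

In this assay, nitro in place of methyl on an aromatic carbon gives a number 55 percentage points higher from compound 2 to compound 4 (beyond the scatter), and set beside the earlier step, this change does not carry over at the same size from one core to the other: the same change on two cores in this assay, a number 5 percentage points higher (within the scatter) from compound 1 to compound 3 and a number 55 percentage points higher (beyond the scatter) from compound 2 to compound 4, 50 percentage points apart, beyond the scatter of two such steps

For the compounds shown here, in these two pairs, then, the size of the step goes with the core that carries it, and only the step on the core of compound 2 lies beyond the scatter, so a step read on one of these cores gives no safe figure for the other. Going by these compounds alone, what this does not show is the reason for the gap, or whether it would appear with any other exchange of groups: there is only one pair for each core, and the place of the entering group, meta to a group of 7 heavy atoms in compound 4, cannot be separated from the rest of the difference between the cores.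

The compounds shown carry only methyl or nitro on the aromatic ring, which leaves open how an amine or a carboxylic acid at the same aromatic carbon would read on either core. They also leave open whether a longer chain between the aromatic ring and the other ring would keep the gap between the two steps.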